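Swapping a methyl ether for an oxolanyl ether

The compounds below may be only part of what the source reports. "The series", "measured", "known", "first", "only" and "open" are said of these compounds alone.

Compound 3 `COc1cc2ncnc(N3CCCc4ccccc43)c2cc1NC(=O)/C=C/CN(C)C` is one of three compounds tested in a functional assay on PC-3 cells (Homo sapiens) for antiproliferative activity, read by MTT assay, with a stated time of 72 h; on this read-out lower numbers stand for stronger inhibition and higher numbers for weaker inhibition. Compound 1 `CC(C)=CC(=O)Nc1cc2c(N3CCCc4ccccc43)ncnc2cc1O[C@@H]1CCOC1` gives 9020 nM, and compound 2 `CN(C)C/C=C/C(=O)Nc1cc2c(N3CCc4ccccc43)ncnc2cc1O[C@@H]1CCOC1` gives 1230 nM. In this assay compound 3 gives 1750 nM, the second highest of the three numbers; it sits within the scatter of compound 2 and well below compound 1. Compound 4 `CN(C)C/C=C/C(=O)Nc1cc2c(N3CCCc4ccccc43)ncnc2cc1O[C@@H]1CCOC1` has not yet been measured. It differs from compound 3 in one place: oxolan-3-yl in place of methyl on an oxygen on an aromatic ring. Going by the values given here, no pair of measured compounds covers exactly this swap. Compound 2 carries the same oxolanyl ether and gives 1230 nM. On that basis the change is expected to produce no step beyond the scatter, a 1.3-fold lower number from compound 3 to compound 4 (0.10 log units; within the scatter). Compound 4 is therefore estimated at 1400 nM, with a range from 500 nM to 4000 nM.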

Compound 4, half-maximal inhibitory concentration: 4170 nM
For compound 4 the middle estimate is 3.0-fold (0.47 log units) below the measured one; the whole stated range lies below it.
By their numbers in this assay, from the lowest: compounds 2 and 3 (each within the scatter of the next); then compound 4; then compound 1.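

In this assay the direct swap from methoxy to (oxolan-3-yl)oxy gives a 2.4-fold higher number from compound 3 to compound 4 (0.38 log units; beyond the scatter) at this oxygen on the aromatic ring, so the larger ether costs activity here. With that ether kept, two other single changes also move the number: the 1,2,3,4-tetrahydroquinolin-1-yl group gives a 3.4-fold higher number from compound 2 to compound 4 (0.53 log units; beyond the scatter) and the 3-(dimethylamino)prop-1-en-1-yl group gives a 2.2-fold lower number from compound 1 to compound 4 (0.34 log units; beyond the scatter) in this set. Nothing measured here explains these steps. On these data alone, whether an ethoxy group or a free hydroxyl on this oxygen would sit nearer compound 3 or compound 4 remains open.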